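Aryl group on the carbonyl carbon: outlook for compound 4

The source may hold more compounds than are shown below. What is called first, only, known or untested is meant among the compounds shown, and "the series" means these compounds.

Measured to date in a functional assay on MDA-MB-231 cells (Homo sapiens) for cytotoxicity, read by MTT assay, with a stated time of 48 h; on this read-out lower numbers stand for stronger inhibition and higher numbers for weaker inhibition:
Compound 1, `O=C(/C=C/c1ccc2c(c1)B(O)OC2)c1ccco1`, gives 7300 nM.
Compound 2, `O=C(/C=C/c1ccc2c(c1)B(O)OC2)c1cccs1`, gives 4600 nM.
Compound 3, `O=C(/C=C/c1ccc2c(c1)B(O)OC2)c1ccccc1O`, gives 16900 nM.

Compound 3 stands highest of the three numbers; the steps of a 2.3-fold higher number from compound 1 to compound 3 (0.36 log units; beyond the scatter) and a 3.7-fold higher number from compound 2 to compound 3 (0.57 log units; beyond the scatter) are both modest yet beyond the scatter. Compound 4, `Nc1cccc(C(=O)/C=C/c2ccc3c(c2)B(O)OC3)c1`, differs from compound 3 by 3-aminophenyl in place of 2-hydroxyphenyl on a carbonyl carbon. Among the measured compounds shown here, no measured step swaps one substituted phenyl for another at this place; the two steps onto compound 3 only show that exchanging the aryl group on the carbonyl carbon shifts the number modestly in this assay. A step of that order in either direction, or none beyond the scatter, is therefore plausible. The estimate for compound 4 is 10000 nM, between 4000 nM and 30000 nM. This corresponds to an expected step of a 1.7-fold lower number from compound 3 to compound 4 (0.23 log units; within the scatter).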

Compound 4, half-maximal inhibitory concentration: 3200 nM
Beside the measured number, compound 4's estimate is 3.1-fold (0.49 log units) above it; the whole stated range lies above it.
By their numbers in this assay, from the lowest: compounds 4, 2 and 1 (each within the scatter of the next, the first and the last beyond it); then compound 3.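

In this assay, 3-aminophenyl in place of 2-hydroxyphenyl on the carbonyl carbon gives a 5.3-fold lower number from compound 3 to compound 4 (0.72 log units; beyond the scatter), so a substituted phenyl at this place is not tied to the high number of compound 3. Against the five-membered aryl groups, the readings are a 2.3-fold lower number from compound 1 to compound 4 (0.36 log units; beyond the scatter) and a 1.4-fold lower number from compound 2 to compound 4 (0.16 log units; within the scatter), the latter leaving those two compounds unseparated. Nothing available bears on the cause of these steps.

Open, going by these compounds, is whether the identity of the substituent or its place on the phenyl ring carries the step from compound 3. A 3-hydroxyphenyl or 2-aminophenyl group on the carbonyl carbon would separate the two.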